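This account rests on a few compounds, and the source may have more. Where it says the series, first, only, none or still open, it means among the compounds named here.

Of the compounds shown here, two have so far been measured in a functional assay on UACC-62 cells (Homo sapiens) for inhibition, read by sulforhodamine B assay, with a stated time of 48 h, tested at 10 uM; a higher number here means more inhibition at the concentration tested (going by the name of the read-out), a lower number less inhibition. Compound 1 `Brc1cn2ccnc2c(-c2ccc3ncn(C4CCCCC4)c3c2)n1` gives 19.8%, and compound 2 `COc1ccccc1-c1cn2ccnc2c(-c2ccc3ncn(C4CCCCC4)c3c2)n1` gives 25.1%. Within the data shown here, the one step between them, a number 5.3 percentage points higher from compound 1 to compound 2 (within the scatter), so the two numbers cannot be told apart. Compound 3 `Fc1ccccc1-c1cn2ccnc2c(-c2ccc3ncn(C4CCCCC4)c3c2)n1` differs from compound 2 in a single place: fluoro in place of methoxy on an aromatic carbon. Among the measured compounds shown here, no measured step exchanges one substituent for another on the six-membered aromatic ring of carbon only; the only step known, a number 5.3 percentage points higher from compound 1 to compound 2 (within the scatter), replaces bromo by the whole 2-methoxyphenyl group and still stays within the scatter. On that basis compound 3 is expected to show a step of a number 3.1 percentage points lower from compound 2 to compound 3 (within the scatter) in this assay, that is, no change beyond the scatter. The estimate for compound 3 in this assay is 22%, with a range from 8% to 36%.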

Compound 3, a percentage reported as inhibition, at one concentration (the size of the read-out at that concentration, not a potency): 38.2%
Beside the measured number, compound 3's estimate is 16.2 percentage points below it, outside the stated range (above it).
By their numbers in this assay, from the lowest: compounds 1 and 2 (each within the scatter of the next); then compound 3.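

In this assay, a change on the six-membered aromatic ring of carbon only, ortho to a large group, now moves the number beyond the scatter: fluoro in place of methoxy gives a number 13.1 percentage points higher from compound 2 to compound 3 (beyond the scatter). The 2-fluorophenyl group in place of bromo gives a number 18.4 percentage points higher from compound 1 to compound 3 (beyond the scatter), while 2-methoxyphenyl in place of bromo gave only a number 5.3 percentage points higher from compound 1 to compound 2 (within the scatter), so what the added ring carries at this place decides whether it separates from bromo. Nothing available offers an explanation for this difference.

The compounds shown leave open whether the higher number follows from fluoro itself or from the loss of methoxy, and how an amine, a chloro group or a plain hydrogen would read at the same place. They also leave open whether the step would hold at other concentrations, since each number is a reading at a single one.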